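This account rests on a few compounds, and the source may have more. Where it says the series, first, only, none or still open, it means among the compounds named here.

In a functional assay on C6 cells (Rattus norvegicus) for cytotoxicity, read by MTT assay, with a stated time of 24 h, tested at 25 ug/mL (on this read-out lower numbers stand for a stronger effect and higher numbers for a weaker effect at the one concentration tested), compound 2 `O=C(CSc1ncccn1)N/N=c1/scc(-c2ccc(Br)cc2)n1-c1ccccc1` gives 72.3%, the highest of the three numbers measured. Compound 1 `O=C(CSc1nnnn1-c1ccccc1)N/N=c1/scc(-c2ccc(Br)cc2)n1-c1ccccc1` gives 47.9% and compound 3 `Cn1nnnc1SCC(=O)N/N=c1/scc(-c2ccc(C#N)cc2)n1-c1ccccc1` gives 43.9%, both lying beyond the scatter below compound 2. For the measured compounds named here, the only measured step, a number 24.4 percentage points higher from compound 1 to compound 2 (beyond the scatter), concerns the group on the sulfur and says nothing about the aryl substituent. Compound 4 `COc1ccc(-c2cs/c(=N/NC(=O)CSc3ncccn3)n2-c2ccccc2)cc1` differs from compound 2 only there: methoxy in place of bromo on an aromatic carbon. Going by the values given here, compound 3 carries another aryl substituent, but it also differs from compound 1 at the sulfur, so no single step separates them. With nothing bearing on this change, compound 4 is expected to stay near compound 2, with a step of a number 2.3 percentage points lower from compound 2 to compound 4 (within the scatter) within the scatter. The estimate for compound 4 is 70%, between 50% and 90%.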

Compound 4, a percentage reported as activity, at one concentration (the size of the read-out at that concentration, not a potency): 74%
For compound 4 the middle estimate is 4 percentage points below the measured one; measured number inside the range.
By their numbers in this assay, from the lowest: compounds 3 and 1 (each within the scatter of the next); then compounds 2 and 4 (each within the scatter of the next).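

In this assay, for the compounds shown here, the change from 4-bromophenyl to 4-methoxyphenyl gives a number 1.7 percentage points higher from compound 2 to compound 4 (within the scatter) and is the only reading at this position with the pyrimidin-2-yl group on the sulfur held fixed. On this aromatic carbon, para to a large group, the read-out does not separate bromo from methoxy, even though methoxy brings one hydrogen-bond acceptor. No measurement at hand offers an explanation for this result. As far as these compounds go, whether an amine or a carboxylic acid here would leave the number equally unmoved remains open. So does whether the same change would behave alike with 1-phenyl-1H-tetrazol-5-yl on the sulfur.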